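The source may hold more compounds than are shown below. What is called first, only, known or untested is meant among the compounds shown, and "the series" means these compounds.

Three compounds have so far been measured in an ADME assay on NHDF cells (Homo sapiens) for cytotoxicity, read by MTT assay, with a stated time of 72 h; on this read-out higher numbers stand for weaker inhibition and lower numbers for stronger inhibition:

Compound 1 `COc1cccc(/C=C2\CCC/C(=C\c3cc(Cl)cc(Cl)c3)C2=O)c1OC`: 21600 nM
Compound 2 `COc1cccc(/C=C2\CCC/C(=C\c3ccc(O)c(Cl)c3)C2=O)c1OC`: 39500 nM
Compound 3 `COc1ccc(/C=C2\CCC/C(=C\c3cc(Cl)cc(Cl)c3)C2=O)cc1OC`: 8300 nM

Compound 3 gives the lowest of the three numbers; its nearest neighbour is compound 1, and the difference between the core of compound 1 and the core of compound 3 is not broken down here. Compound 1 and compound 2 differ in one place, (3-chloro-4-hydroxyphenyl in place of 3,5-dichlorophenyl on a double-bonded chain carbon bound to a double-bonded ring carbon), and this change gave a 1.8-fold higher number from compound 1 to compound 2 (0.26 log units; within the scatter).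

Compound 4 `COc1ccc(/C=C2\CCC/C(=C\c3ccc(O)c(Cl)c3)C2=O)cc1OC` has not yet been measured. It stands to compound 3 exactly as compound 2 stands to compound 1: the change is 3-chloro-4-hydroxyphenyl in place of 3,5-dichlorophenyl on a double-bonded chain carbon bound to a double-bonded ring carbon, the same change at the same place, made here on the core of compound 3. The step from compound 3 to compound 4 is expected to be a 1.8-fold higher number from compound 3 to compound 4 (0.26 log units; within the scatter), because the identical change gave a 1.8-fold higher number from compound 1 to compound 2 (0.26 log units; within the scatter), a step that stayed within the scatter. For compound 4 the estimate in this assay is therefore 15000 nM, with the expected range from 7000 nM to 35000 nM.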

Compound 4, half-maximal inhibitory concentration: 21900 nM
The estimate for compound 4 lay 1.5-fold (0.16 log units) below the measured number, within the range that was stated.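

In this assay, putting 3-chloro-4-hydroxyphenyl in place of 3,5-dichlorophenyl on the core of compound 3 gave a 2.6-fold higher number from compound 3 to compound 4 (0.42 log units; beyond the scatter). Set beside the step on the core of compound 1, this shows that the size of the change carried from one core to the other, as far as these data can tell: the same change on two cores in this assay, a 1.8-fold higher number (0.26 log units; within the scatter) from compound 1 to compound 2 and a 2.6-fold higher number (0.42 log units; beyond the scatter) from compound 3 to compound 4, 1.4-fold (0.16 log units) apart, within the scatter of two such steps It does not show that the effect is established on both cores alone, since only the step on the core of compound 3 lies beyond the scatter, and two cores give no basis for predicting the change on any other core or for saying why the number moves.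

The compounds shown leave open how the number would respond to other groups at this place, such as a phenyl ring bearing an amine or a carboxylic acid. They also leave open whether the hydroxyl or the loss of one chlorine accounts for the step, as the change replaces both at once.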